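Swapping a dienyl chain for a methoxybenzyl group

This account rests on a few compounds, and the source may have more. Where it says the series, first, only, none or still open, it means among the compounds named here.

Compound 1, `CCCCCCn1cnc2c(Nc3cccc(Cl)c3)nc(N[C@H]3CC[C@H](N)CC3)nc21`, gives 10200 nM in a functional assay on HCC827 cells (Homo sapiens) for inhibition, read by fluorescence, with a stated time of 72 h; a lower number here means a stronger inhibitor of growth, a higher number a weaker inhibitor of growth.
Compound 2, `CC(C)=CCn1cnc2c(Nc3cccc(Cl)c3)nc(N[C@H]3CC[C@H](N)CC3)nc21`, gives 13500 nM in this assay.
Compound 3, `CC(C)=CCC/C(C)=C/Cn1cnc2c(Nc3cccc(Cl)c3)nc(N[C@H]3CC[C@H](N)CC3)nc21`, gives 18200 nM in this assay.

Compound 3 has the highest number of the three, but its neighbours sit close: a 1.3-fold higher number from compound 2 to compound 3 (0.13 log units; within the scatter) and a 1.8-fold higher number from compound 1 to compound 3 (0.25 log units; within the scatter), both within the scatter, as is a 1.3-fold higher number from compound 1 to compound 2 (0.12 log units; within the scatter). Across these three compounds the group on the saturated chain carbon bound to the aromatic nitrogen has varied without any step that can be told from repeat measurements.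

Compound 4, `COc1ccc(Cn2cnc3c(Nc4cccc(Cl)c4)nc(N[C@H]4CC[C@H](N)CC4)nc32)cc1`, is the next member of this set. Its change from compound 3 is 4-methoxyphenyl in place of 2,6-dimethylhepta-1,5-dien-1-yl on a saturated chain carbon bound to an aromatic nitrogen. For the measured compounds named here, none of the measured steps involves an aromatic ring at this place, so no step bears directly on it; the three measured steps only show that variation at this position has so far left the number essentially unchanged. Compound 4 is therefore expected to land near compound 3, with a step of about a 1.5-fold lower number from compound 3 to compound 4 (0.18 log units; within the scatter) in this assay and a generous range: the estimate for compound 4 is 12000 nM, between 3500 nM and 40000 nM.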

Compound 4, concentration for 50% growth inhibition: 18700 nM
For compound 4 the middle estimate is 1.6-fold (0.19 log units) below the measured one; the measured number falls inside the stated range.
By their numbers in this assay, from the lowest: compounds 1, 2, 3 and 4 (each within the scatter of the next).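

In this assay, the only aromatic ring at this place, 4-methoxyphenyl, cannot be told apart from any of the three open chains it was compared with (a 1.0-fold higher number from compound 3 to compound 4 (0.01 log units; within the scatter); a 1.4-fold higher number from compound 2 to compound 4 (0.14 log units; within the scatter); a 1.8-fold higher number from compound 1 to compound 4 (0.26 log units; within the scatter)). On the saturated chain carbon bound to an aromatic nitrogen, then, exchanging 2,6-dimethylhepta-1,5-dien-1-yl for a six-membered aromatic ring of carbon only with one hydrogen-bond acceptor has no effect that can be read in this measurement. Nothing at hand offers an explanation for this flat result.

The compounds shown leave open whether an amine or a carboxylic acid on such a chain, or a pyridine ring in place of the 4-methoxyphenyl, would move the number. They also leave open whether any group at this place can bring the number clearly down.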